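This account rests on a few compounds, and the source may have more. Where it says the series, first, only, none or still open, it means among the compounds named here.

Of the compounds shown here, two have been measured so far in a functional assay on K562 cells (Homo sapiens) for antiproliferative activity, read by MTT assay, with a stated time of 5 days; a lower number here means a stronger inhibitor, a higher number a weaker inhibitor. Compound 1, with the structure `COc1cc(C(=O)C(=Cc2ccccc2)c2ccc(C)cc2)cc(OC)c1OC`, gives 2970000 nM, the higher of the two numbers. Compound 2, with the structure `COc1ccc(/C=C(/C(=O)c2cc(OC)c(OC)c(OC)c2)c2ccccc2O)cc1`, gives 370000 nM in this assay, a lower number than compound 1 by a gap that is beyond the usual scatter. Both numbers are very high, so neither compound is a strong inhibitor.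

The unmeasured compound 3, with the structure `COc1ccc(C=C(C(=O)c2cc(OC)c(OC)c(OC)c2)c2ccc(C)cc2)cc1[N+](=O)[O-]`, is built from compound 1 by one change: 4-methoxy-3-nitrophenyl in place of phenyl on a double-bonded chain carbon bound to a double-bonded chain carbon.

Among the measured compounds shown here, no measured pair shows what such a change does here, so the expectation leans only on the fact that compound 2, which also carries a methoxy-bearing ring in that region, sits at 370000 nM. A step of moderate size toward a lower number is therefore expected, a 5.9-fold lower number from compound 1 to compound 3 (0.77 log units; beyond the scatter), though the outcome could still be within the scatter of compound 1. Compound 3 is estimated at 500000 nM in this assay, with a range from 120000 nM to 2000000 nM.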

Compound 3, half-maximal inhibitory concentration: 2430000 nM
Compound 3: the middle estimate sits 4.9-fold (0.69 log units) below what was measured; measured number above the stated range.
By their numbers in this assay, from the lowest: compound 2; then compounds 3 and 1 (each within the scatter of the next).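

In this assay, putting 4-methoxy-3-nitrophenyl in place of phenyl on a double-bonded chain carbon bound to a double-bonded chain carbon gives a 1.2-fold lower number from compound 1 to compound 3 (0.09 log units; within the scatter). Among the compounds shown here, this is the first direct reading at this place, and it shows that the larger group, with its added methoxy and nitro, leaves compound 3 indistinguishable from compound 1 in this assay, with both still very weak. No available evidence explains this result.

This single pair cannot show whether the methoxy and the nitro each have no effect on their own or whether their effects cancel out. It also leaves open whether a quite different group at this place, such as an amine or a carboxylic acid on the ring, would move the number beyond the scatter.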